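Sulfamoyl carbamates: anilino replacing dibutylamino on compound 3

The source may report more compounds than this note shows. Statements on the series, on what has been measured and on what is new or still open speak of the compounds shown alone.

Within the three measured members, compound 3 `CCCCN(CCCC)S(=O)(=O)NC(=O)Oc1c(C(C)(C)C)cc(C)cc1C(C)(C)C` holds the lowest number in an assay on liver for inhibition of sterol O-acyltransferase 1 (Rattus norvegicus), using microsomes (on this read-out higher numbers stand for weaker inhibition and lower numbers for stronger inhibition), giving 3200 nM. Compound 2 `CCCCCCNS(=O)(=O)NC(=O)Oc1c(C(C)(C)C)cc(C)cc1C(C)(C)C` gives 19400 nM, and compound 1 `CC(C)c1cccc(C(C)C)c1OC(=O)NS(=O)(=O)Nc1ccccc1` gives 38100 nM. Within the data shown here, the one single-point step seen so far, a 6.1-fold lower number from compound 2 to compound 3 (0.78 log units; beyond the scatter), shows that a doubly alkylated sulfonyl nitrogen sits at a lower number than a singly alkylated one. Compound 4 `Cc1cc(C(C)(C)C)c(OC(=O)NS(=O)(=O)Nc2ccccc2)c(C(C)(C)C)c1` differs from compound 3 by anilino in place of dibutylamino on a sulfonyl sulfur. The change reintroduces a hydrogen-bond donor at this nitrogen, in the direction opposite to the step from compound 2 to compound 3; compound 1 likewise bears anilino on its sulfonyl sulfur and gives the highest number of the set. In this assay compound 4 is therefore expected to give a higher number, around 20000 nM (range 6000 nM to 60000 nM), a step of a 6.3-fold higher number from compound 3 to compound 4 (0.80 log units; beyond the scatter) estimated from compound 3.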

Compound 4, half-maximal inhibitory concentration: 23400 nM
Estimate against measurement, compound 4: 1.2-fold (0.07 log units) below; the measured number falls inside the stated range.
By their numbers in this assay, from the lowest: compound 3; then compounds 2, 4 and 1 (each within the scatter of the next).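

In this assay, anilino on the sulfonyl sulfur does not keep the lower number of dibutylamino (a 7.3-fold higher number from compound 3 to compound 4 (0.86 log units; beyond the scatter)). Phenyl and hexyl on a sulfonamide nitrogen cannot be told apart (a 1.2-fold higher number from compound 2 to compound 4 (0.08 log units; within the scatter)), so an aromatic ring and a straight chain on this nitrogen read alike here. Among these compounds, on the shared core, the lower number so far belongs only to doubly alkylated compound 3.

Whether dipropylamino, N-methylanilino or piperidinyl on the sulfonyl sulfur would match compound 3 remains open, and no measurement at hand accounts for these steps.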